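Cyano to acetamido on compound 1: working notes

The compounds below may be only part of what the source reports. "The series", "measured", "known", "first", "only" and "open" are said of these compounds alone.

Measured in a functional assay on PC-3 cells (Homo sapiens) for inhibition, read by sulforhodamine B assay, with a stated time of 48 h, tested at 50 uM; on this read-out higher numbers stand for more inhibition of growth at the one concentration tested and lower numbers for less inhibition of growth:
- compound 1 `COc1ccc([C@@H]2C/C(=N/OCc3cn(-c4ccc(C#N)cc4)nn3)c3cc(CC=C(C)C)c(OC)cc3O2)cc1`: 50%
- compound 2 `COc1cc2c(cc1CC1OC1(C)C)C(=O)C[C@@H](c1ccc(O)cc1)O2`: 92%
- compound 3 `COc1cc2c(cc1CC=C(C)C)/C(=N/O)C[C@@H](c1ccc(O)cc1)O2`: 81%

Compound 1 stands lowest of the three at 50%. Compound 3 is the nearest to it with 81%, and compound 2 is the furthest from it with 92%. Both gaps are beyond the scatter.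

The next compound to be read is compound 4 `COc1ccc([C@@H]2C/C(=N/OCc3cn(-c4ccc(NC(C)=O)cc4)nn3)c3cc(CC=C(C)C)c(OC)cc3O2)cc1`, which keeps the rest of compound 1 and carries acetamido in place of cyano on an aromatic carbon.

For the measured compounds named here, no measured pair isolates this change, and compounds 2 and 3 differ from compound 1 in more than one place. The expectation therefore starts from compound 1 at 50%. Going by these compounds, no step beyond the scatter is expected in this assay, and the direction remains open. The estimated step of a number 2 percentage points lower from compound 1 to compound 4 (within the scatter) is small.

For compound 4 the estimated value is 48%, with an expected range from 28% to 68%.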

Compound 4, percent growth inhibition at one concentration: 2%
Beside the measured number, compound 4's estimate is 46 percentage points above it, and the stated range ends above it.
By their numbers in this assay, from the lowest: compound 4; then compound 1; then compound 3; then compound 2.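

Acetamido in place of cyano on an aromatic carbon gives a number 48 percentage points lower from compound 1 to compound 4 (beyond the scatter) in this assay, and this is the only comparison in the series that isolates a single place. Compounds 2 and 3 differ from compound 1 in more than one place, so they could not show that this one group, para to a large group, can on its own change the growth inhibition this strongly. No measured evidence here accounts for the size of this step.

Going by these compounds, how other groups at this place would read remains open, for example an amine, a carboxylic acid or a longer acyl chain on the amide nitrogen. Also open, on these data alone, is whether 4-cyanophenyl to 4-acetamidophenyl would give a similar step with other parts of compound 1 changed.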